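The source may report more compounds than this note shows. Statements on the series, on what has been measured and on what is new or still open speak of the compounds shown alone.

Measured in a functional assay on HEK293 cells for agonist activity at G-protein coupled receptor 39 (Homo sapiens), read by scintillation proximity assay and inositol phosphate accumulation, with a stated time of 75 min, in the presence of a further agent that is not named here; on this read-out higher numbers stand for an effect only at larger amounts of compound and lower numbers for an effect already at smaller amounts:
compound 1 `Cc1nn(-c2ncnc3nc[nH]c23)c2c1C(OC1CCCC1)CC(=O)N2`: 2 nM
compound 2 `Cc1nn(-c2ncnc3nc[nH]c23)c2c1C(OCc1ccccc1F)CC(=O)N2`: 4 nM
compound 3 `CCCCCCCCOC1CC(=O)Nc2c1c(C)nn2-c1ncnc2nc[nH]c12`: 8 nM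

Compound 3 carries the largest number of the three; against compound 1 the gap is a 4.0-fold higher number from compound 1 to compound 3 (0.60 log units; beyond the scatter), against compound 2 only a 2.0-fold higher number from compound 2 to compound 3 (0.30 log units; within the scatter), so compound 3 and compound 2 are not separated.

Compound 4 `Cc1nn(-c2ncnc3nc[nH]c23)c2c1C(OCc1ccc(C(C)C)cc1)CC(=O)N2` is not yet measured. It differs from compound 3 by 4-isopropylphenyl in place of heptyl on a saturated chain carbon bound to an oxygen on a saturated carbon. The step that bears on this is the earlier exchange of an aryl group for a chain at the same place, a 2.0-fold higher number from compound 2 to compound 3 (0.30 log units; within the scatter), together with a 2.0-fold higher number from compound 1 to compound 2 (0.30 log units; within the scatter), both small. Returning from heptyl to an aryl group is therefore expected to give a small step back toward smaller numbers, a 2.0-fold lower number from compound 3 to compound 4 (0.30 log units; within the scatter), likely within the scatter. Compound 4 is estimated at 4 nM, with a range of 1.5 nM to 12 nM.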

Compound 4, half-maximal effective concentration: 5 nM
Estimate against measurement, compound 4: 1.3-fold (0.10 log units) below, within the range that was stated.
By their numbers in this assay, from the lowest: compounds 1, 2, 4 and 3 (each within the scatter of the next, the first and the last beyond it).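

On an oxygen on a saturated carbon, 4-isopropylbenzyl is not separated from octyl (a 1.6-fold lower number from compound 3 to compound 4 (0.20 log units; within the scatter)) or from 2-fluorobenzyl (a 1.3-fold higher number from compound 2 to compound 4 (0.10 log units; within the scatter)) in this assay. Cyclopentyl alone stands apart from it (a 2.5-fold higher number from compound 1 to compound 4 (0.40 log units; beyond the scatter)), so the benzyl ring carries 4-isopropyl with no step beyond the scatter relative to 2-fluoro. No measurement at hand explains these steps.

Still open, as far as these compounds go, is whether an amine or a carboxylic acid on the benzyl ring keeps numbers of this order. Also open, from the compounds shown here alone, is how a smaller group, such as methyl, compares with cyclopentyl at this place.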